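From Chloro to Trifluoromethyl in a Cell Assay

The source may report more compounds than this note shows. Statements on the series, on what has been measured and on what is new or still open speak of the compounds shown alone.

In a functional assay on HL-60 cells (Homo sapiens) for cytotoxicity, read by luminescence and CellTiter-Glo, with a stated time of 3 days (a higher number here means a weaker inhibitor, a lower number a stronger inhibitor), compound 1 `COc1ccc(O)c(C(=O)Nc2ccc(C#N)cc2)c1` gives > 10000 nM, which is a limit of the assay and not a number. Compound 2 `N#Cc1ccc(NC(=O)c2cc(-c3ccccc3)ccc2O)cc1` gives 1350 nM and compound 3 `N#Cc1ccc(NC(=O)c2cc(Cl)ccc2O)cc1` gives 700 nM, two values within the scatter of each other. Compound 4 `N#Cc1ccc(NC(=O)c2cc(C(F)(F)F)ccc2O)cc1` has trifluoromethyl in place of chloro on an aromatic carbon. Replacing methoxy made a clear difference, with an at least 7.4-fold lower number from compound 1 to compound 2 (0.86 log units; beyond the scatter) and an at least 14-fold lower number from compound 1 to compound 3 (1.15 log units; beyond the scatter). Exchanging phenyl for chloro did not, with a 1.9-fold lower number from compound 2 to compound 3 (0.29 log units; within the scatter), so this further exchange of one group for another is expected to change little. The estimated step is a 1.2-fold lower number from compound 3 to compound 4 (0.07 log units; within the scatter), which is expected to stay within the scatter. For compound 4 the estimate is 600 nM, with an expected range of 250 nM to 1500 nM.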

Compound 4, half-maximal inhibitory concentration: 3120 nM
Estimate against measurement, compound 4: 5.2-fold (0.72 log units) below, outside the stated range (above it).
By their numbers in this assay, from the lowest: compounds 3 and 2 (each within the scatter of the next); then compound 4. At a limit, above all of these: compound 1.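

Among the groups other than methoxy, this position, para to a hydroxy group, now proves sensitive to the group it carries, with a 4.5-fold higher number from compound 3 to compound 4 (0.65 log units; beyond the scatter) and a 2.3-fold higher number from compound 2 to compound 4 (0.36 log units; beyond the scatter). Trifluoromethyl still gives a lower number than methoxy in this assay, with an at least 3.2-fold lower number from compound 1 to compound 4 (0.50 log units; beyond the scatter). Compound 1 stands at a limit of the assay, not at a number: the limit of > 10000 nM in this assay, at which 1 of the 4 values shown sits.

No simple order by group emerges, since compound 2 and compound 3 lie within the scatter of each other while compound 4 lies above both. From the compounds shown here alone, how an amine, a carboxylic acid or a longer chain would read at this position stays open.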